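The compounds below may be only part of what the source reports. "The series", "measured", "known", "first", "only" and "open" are said of these compounds alone.

Going by the values given here, compound 3 `COc1ccc(C(C)Sc2nc3c(cnn3C)c(=O)n2-c2ccccc2)cc1` gives 352 nM in an assay on isolated protein for inhibition of aldehyde dehydrogenase 1A1 (Homo sapiens) (on this read-out higher numbers stand for weaker inhibition and lower numbers for stronger inhibition), which places it second highest among the three numbers so far. Its nearest neighbour is compound 2 `CCC(Sc1nc2c(cnn2C)c(=O)n1-c1ccccc1)c1ccccc1`, which gives 150 nM in this assay, and furthest from it is compound 1 `Cn1ncc2c(=O)n(-c3ccccc3)c(SC(C)(C)c3ccccc3)nc21`, which gives 1900 nM. Among the compounds with values here, the only step between two compounds that differ in a single place is a 13-fold lower number from compound 1 to compound 2 (1.10 log units; beyond the scatter), and that step concerns the chain on the sulfur, not the aromatic ring at its end.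

Compound 4 `CC(Sc1nc2c(cnn2C)c(=O)n1-c1ccccc1)c1cccc(O)c1` is not yet measured. It differs from compound 3 by 3-hydroxyphenyl in place of 4-methoxyphenyl on a saturated chain carbon bound to a saturated chain carbon and a sulfur. Within the data shown here, no measured pair separates the group on that ring from the rest of the molecule, so no step bears on this change, and there is no ground for expecting a move in either direction beyond the scatter. On that basis the expected step is a 1.1-fold higher number from compound 3 to compound 4 (0.06 log units; within the scatter), with a wide range. Compound 4 is therefore estimated at 400 nM in this assay, between 120 nM and 1400 nM.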

Compound 4, half-maximal inhibitory concentration: 130 nM
Compound 4: the middle estimate sits 3.1-fold (0.49 log units) above what was measured; the range from low to high includes it.
By their numbers in this assay, from the lowest: compounds 4 and 2 (each within the scatter of the next); then compound 3; then compound 1.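

Going by these compounds alone, the ring at the end of the sulfur chain matters as well as the chain itself: in this assay, a 2.7-fold lower number from compound 3 to compound 4 (0.43 log units; beyond the scatter) is the first step to concern that ring, and it lies beyond the scatter. Alongside it, a 1.2-fold lower number from compound 2 to compound 4 (0.06 log units; within the scatter) lies within the scatter, so the change to the ring reaches the level of the change to the chain, while a 15-fold lower number from compound 1 to compound 4 (1.16 log units; beyond the scatter) leaves the fully substituted chain of compound 1 clearly apart from both. Nothing measured here accounts for these steps.

The step from 4-methoxyphenyl to 3-hydroxyphenyl alters the group and its place on the ring together, and 3-methoxyphenyl or 4-hydroxyphenyl would be needed to separate the two. As far as these compounds go, whether an amine or a carboxylic acid at that place on the ring would hold the lower number also stays open.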